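The source may hold more compounds than are shown below. What is called first, only, known or untested is meant among the compounds shown, and "the series" means these compounds.

Measured so far in an ADME assay on Caco-2 cells (Homo sapiens) for inhibition, read by MTT assay, with a stated time of 72 h; a higher number here means a weaker inhibitor, a lower number a stronger inhibitor:
- compound 1 `COc1cc(/C=C/C(=O)/C=C(/C=C/c2ccc(OC(C)=O)c(OC)c2)NC2CCCCC2)ccc1OC(C)=O` at > 25000 nM (a limit of the assay)
- compound 2 `CCCNC(=C\C(=O)/C=C/c1ccc(O)c(OC)c1)/C=C/c1ccc(O)c(OC)c1` at > 25000 nM (a limit of the assay)

Compound 2 has no number, only a limit, and it stands with compound 1 at the limit of > 25000 nM in this assay, at which 2 of the 2 values shown sit, in this series. Compound 3 `CCC(C)NC(=C\C(=O)/C=C/c1ccc(O)c(OC)c1)/C=C/c1ccc(O)c(OC)c1` differs from compound 2 by methyl in place of hydrogen on a saturated chain carbon bound to an amine nitrogen and a saturated chain carbon and so reads propyl to sec-butyl. The step expected in this assay is a step that the limit leaves unreadable from compound 2 to compound 3 and is estimated to stay within the scatter, in no set direction. Compound 3 is estimated at 30000 nM with an expected range from 15000 nM to 60000 nM. Compound 3 may well be expected to give only a limit.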

Compound 3, half-maximal inhibitory concentration: > 25000 nM
Compound 3: only a limit was reported (the forecaster's own chance of this, stated with the estimate: 75%); the middle value lies beyond the limit too.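

In this assay no step can be read from compound 2 to compound 3, as both results are limits: the limit of > 25000 nM in this assay, at which 3 of the 3 values shown sit.
The compounds shown leave open whether sec-butyl and propyl differ at all, and where any true inhibitory value lies.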